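The compounds below may be only part of what the source reports. "The series", "measured", "known", "first", "only" and "open" are said of these compounds alone.

Measured in a functional assay on BXPC-3 cells (Homo sapiens) for cytotoxicity, read by MTT assay, with a stated time of 72 h; on this read-out higher numbers stand for weaker inhibition and lower numbers for stronger inhibition:
- compound 1 `CC(C)(C)c1[nH]cnc1/C=c1\[nH]c(=O)/c(=C/c2cccc(C(=O)c3ccc(F)cc3)c2)[nH]c1=O`: 0.6 nM
- compound 2 `CC(C)c1[nH]cnc1/C=c1\[nH]c(=O)/c(=C/c2cccc(C(=O)c3ccc(F)cc3)c2)[nH]c1=O`: 0.6 nM

Level with compound 1, compound 2 sits at 0.6 nM. Compound 3 `COCc1ccc(/C=c2\[nH]c(=O)/c(=C/c3cccc(C(=O)c4ccc(F)cc4)c3)[nH]c2=O)o1` makes a larger change: 5-(methoxymethyl)furan-2-yl in place of 5-isopropyl-1H-imidazol-4-yl on a double-bonded chain carbon bound to an aromatic carbon. For the measured compounds named here, the only measured step, no change at the digits printed from compound 1 to compound 2 (within the scatter), removes one methyl and leaves that ring in place, so it offers little guidance. Going by the values given here, no measured compound lacks the ring, so only a modest weakening in this assay is expected, with wide uncertainty. The estimated step is a 5.0-fold higher number from compound 2 to compound 3 (0.70 log units; beyond the scatter). For compound 3 the estimate is 3 nM, with an expected range of 0.6 nM to 20 nM.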

Compound 3, half-maximal inhibitory concentration: 2 nM
The estimate for compound 3 lay 1.5-fold (0.18 log units) above the measured number; low and high end bracket the measured number.
By their numbers in this assay, from the lowest: compounds 1 and 2 (each within the scatter of the next); then compound 3.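

In this assay, replacing the imidazole ring with 5-(methoxymethyl)futan-2-yl on this double-bonded chain carbon costs only a modest amount of potency (a 3.3-fold higher number from compound 2 to compound 3 (0.52 log units; beyond the scatter)) and (a 3.3-fold higher number from compound 1 to compound 3 (0.52 log units; beyond the scatter)). The entering ring has no hydrogen-bond donor, yet compound 3 still gives 2 nM, so a donor on this ring is not required for a low nanomolar number in this series. No available data explain the size of this step.

Going by these compounds, the ring and its substituent change together, so their separate contributions remain unknown. Also open, on these data alone, is how a furan carrying an amine or a carboxylic acid instead of methoxymethyl would compare.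

Correction: "futan" above should read "furan", giving 5-(methoxymethyl)furan-2-yl.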